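Methyl Added to the Oxadiazole Chain: Cytotoxicity Outlook

The source may hold more compounds than are shown below. What is called first, only, known or untested is meant among the compounds shown, and "the series" means these compounds.

Compound 2 `CCc1nc(-c2ccc(OCCC(C)CCN3CCN(c4ccncc4)C3=O)cc2)no1` was tested in an ADME assay on cells (Homo sapiens) for cytotoxicity; a higher number here means that more compound is tolerated, a lower number that less compound is tolerated. There compound 2 gives > 25000 nM, which is a limit of the assay rather than a number. Two companions sharing the same core were run in the same test. Compound 1 `O=C1N(CCC(CCOc2ccc(-c3ccc(Cl)cc3)cc2)Cc2ccccc2)CCN1c1ccncc1` gives > 10000 nM in this assay, again a limit. Compound 3 `Cc1cc(COc2ccc(-c3ccc(Cl)cc3)cc2)cc(CN2CCN(c3ccncc3)C2=O)c1` gives > 25000 nM in this assay, also a limit. Going by the values given here, the whole picture is therefore made of limits, the limit of > 10000 nM in this assay, at which 1 of the 3 values shown sits, and (the limit of > 25000 nM in this assay, at which 2 of the 3 values shown sit), so no step between measured compounds can be sized and nothing separates compound 2 from the other two.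

Compound 4 `CCCc1nc(-c2ccc(OCCC(C)CCN3CCN(c4ccncc4)C3=O)cc2)no1` has not yet been tested in this assay. It differs from compound 2 by methyl in place of hydrogen on a saturated chain carbon, two bonds along the chain from an aromatic carbon. Among the compounds with values here, with every value at a limit and no measured step to draw on, the step in this assay is expected to be none beyond the scatter, and the outcome is expected to be a limit once more. The step is expected to be a step that the limit leaves unreadable from compound 2 to compound 4. Compound 4 is expected to give 30000 nM, in a range from 15000 nM to 60000 nM.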

Compound 4, half-maximal cytotoxic concentration: > 12500 nM
Compound 4: no number, only a limit; the forecaster's own chance of this, stated with the estimate: 80%; the middle value is on the limit's open side.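

In this assay compound 4 gives > 12500 nM, which is a limit of the assay. Going by these compounds alone, compound 2 also stands at a limit, so no step from it to compound 4 can be read. The compounds shown leave open what half-maximal cytotoxic concentration any of them actually has.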